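The compounds below may be only part of what the source reports. "The series", "measured", "known", "first", "only" and "open" are said of these compounds alone.

Compound 3 `C=CCSC[C@H](NC(=O)c1cc(O)c(O)c(O)c1)C(=O)OC` in an assay on RAW264.7 cells for antagonist activity at Toll-like receptor 2 (Mus musculus), read by Griess assay, with a stated time of 24 h (on this read-out lower numbers stand for stronger inhibition and higher numbers for weaker inhibition), gives 52100 nM, which sits at the high end of the three numbers shown, though compound 1 `C=CCSC[C@H](NC(=O)c1cc(OC)c(OC)c(OC)c1)C(=O)OC` at 49300 nM and compound 2 `COC(=O)[C@H](CSCc1ccc(F)cc1)NC(=O)c1cc(OC)c(OC)c(OC)c1` at 28600 nM both fall within the usual scatter of it. Compound 4 `COC(=O)[C@H](CSCc1ccc(F)cc1)NC(=O)c1cc(O)c(O)c(O)c1` differs from compound 3 by 4-fluorophenyl in place of vinyl on a saturated chain carbon bound to a sulfur. Among the compounds with values here, one measured step matches this change exactly: a 1.7-fold lower number from compound 1 to compound 2 (0.24 log units; within the scatter), which stayed within the scatter, and it is the only guide available. Compound 4 is therefore expected to land near compound 3, with a step of about a 1.6-fold lower number from compound 3 to compound 4 (0.21 log units; within the scatter) that is not expected to exceed the scatter. The estimate for compound 4 in this assay is 32000 nM, expected to fall between 15000 nM and 70000 nM.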

Compound 4, half-maximal inhibitory concentration: 50200 nM
Beside the measured number, compound 4's estimate is 1.6-fold (0.20 log units) below it; low and high end bracket the measured number.
By their numbers in this assay, from the lowest: compounds 2, 1, 4 and 3 (each within the scatter of the next).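

The change from allylsulfanyl to (4-fluorobenzyl)sulfanyl now has a second reading, on the core of compound 3, and in this assay it again stays within the scatter, with a 1.0-fold lower number from compound 3 to compound 4 (0.02 log units; within the scatter). Even a six-membered aromatic ring in place of vinyl therefore gives no readable shift on either core. The two readings agree: the same change on two cores in this assay, a 1.7-fold lower number (0.24 log units; within the scatter) from compound 1 to compound 2 and a 1.0-fold lower number (0.02 log units; within the scatter) from compound 3 to compound 4, 1.7-fold (0.22 log units) apart, within the scatter of two such steps. Still open, on these data alone, is whether an amine, a carboxylic acid or a longer chain at this position would move the number beyond the scatter. No change at this position has yet produced a step larger than the scatter.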